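Methoxy on the pendant phenyl of the imidazopyrazine series

The source may report more compounds than this note shows. Statements on the series, on what has been measured and on what is new or still open speak of the compounds shown alone.

Two compounds of the series have numbers in a functional assay on MCF7 cells (Homo sapiens) for inhibition, read by sulforhodamine B assay, with a stated time of 48 h, tested at 10 uM; on this read-out lower numbers stand for less inhibition and higher numbers for more inhibition at the one concentration tested (going by the name of the read-out). Compound 1 `Brc1cn2ccnc2c(-c2ccc3ncn(C4CCCCC4)c3c2)n1` gives 47.6%. Compound 2 `c1ccc(-c2cn3ccnc3c(-c3ccc4ncn(C5CCCCC5)c4c3)n2)cc1`, with phenyl in place of bromo on an aromatic carbon, gives 38%. Within the data shown here, the one step so far, a number 9.6 percentage points lower from compound 1 to compound 2 (within the scatter), lies within the scatter, so compound 2 stands as the lower of two numbers that cannot be told apart.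

Compound 3 `COc1ccc(-c2cn3ccnc3c(-c3ccc4ncn(C5CCCCC5)c4c3)n2)cc1` is next in line. It differs from compound 2 by methoxy in place of hydrogen on an aromatic carbon. Among the measured compounds shown here, no measured step touches this change directly; the only step in hand, a number 9.6 percentage points lower from compound 1 to compound 2 (within the scatter), concerns the larger exchange of bromo for phenyl and was itself within the scatter. Nothing here points to a step beyond the scatter in either direction for this assay.

Compound 3 is therefore expected to sit close to compound 2, with a number 2 percentage points higher from compound 2 to compound 3 (within the scatter) as the assumed step. The estimate for compound 3 is 40%, within a range of 22% to 58%.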

Compound 3, a percentage reported as inhibition, at one concentration (the size of the read-out at that concentration, not a potency): 80.2%
Compound 3: the middle estimate sits 40.2 percentage points below what was measured, outside the stated range (above it).
By their numbers in this assay, from the lowest: compounds 2 and 1 (each within the scatter of the next); then compound 3.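

Working notes on the pendant phenyl: in this assay the place para to a large group on this ring proves responsive, since methoxy in place of hydrogen gives a number 42.2 percentage points higher from compound 2 to compound 3 (beyond the scatter) and so separates two compounds by more than the scatter. The unsubstituted phenyl had given no step beyond the scatter against bromo, whereas the exchange of bromo for 4-methoxyphenyl gives a number 32.6 percentage points higher from compound 1 to compound 3 (beyond the scatter) in the same read-out, so the change from bromo now registers once the methoxy is present. With both of its steps beyond the scatter, compound 3 has the highest number of the three compounds at the one concentration tested, and no measurement in hand bears on the reason for this step.

As far as these compounds go, a single substituent at a single place cannot show whether the gain is particular to methoxy, so it remains open how a hydroxy, an ethoxy, a dimethylamino or a carboxylic acid at the same place would read. Also open, from the compounds shown here alone, is whether methoxy on another carbon of the phenyl ring would give a step of similar size, and whether the number at this one concentration would carry over to a full potency measurement.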